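Swapping trifluoromethyl for fluoro in a sulfonyl-urea series

This account rests on a few compounds, and the source may have more. Where it says the series, first, only, none or still open, it means among the compounds named here.

Three compounds that share one core have been run through a physicochemical assay for pharmacokinetics; on this read-out lower numbers stand for a shorter-lived compound and higher numbers for a longer-lived compound. Compound 1, `O=C(NCc1ccccc1C(F)(F)F)N1C(=O)c2ccccc2S1(=O)=O`, gives 0.187 h. Compound 2, `O=C(NCc1cccc2ccccc12)N1C(=O)c2ccccc2S1(=O)=O`, gives 0.395 h. Compound 3, `CC(NC(=O)N1C(=O)c2ccccc2S1(=O)=O)c1ccccc1`, gives 0.663 h. On these three numbers compound 1 stands lowest: the nearest value belongs to compound 2, whose number is higher by a margin beyond the usual scatter, and the furthest belongs to compound 3, whose number is higher still, also beyond the scatter. Compound 1 is therefore the shortest-lived of the three in this assay.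

Compound 4, `O=C(NCc1ccccc1F)N1C(=O)c2ccccc2S1(=O)=O`, differs from compound 1 in a single place. The change is fluoro in place of trifluoromethyl on an aromatic carbon. The group that leaves is trifluoromethyl, the group that enters is fluoro, and the site is an aromatic carbon of a six-membered aromatic ring of carbon only, ortho to a large group.

Within the data shown here, no pair of measured compounds shows this particular change, so its effect in this assay has not been seen directly. Because compound 1 already sits at 0.187 h, the step of a 1.3-fold higher number from compound 1 to compound 4 (0.13 log units; within the scatter) is expected to be small, with no clear direction beyond the scatter. For compound 4 the expected half-life is 0.25 h, estimated to lie between 0.12 h and 0.55 h.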

Compound 4, half-life: 0.598 h
For compound 4 the middle estimate is 2.4-fold (0.38 log units) below the measured one; the measured number lies above the stated range.
By their numbers in this assay, from the lowest: compound 1; then compounds 2, 4 and 3 (each within the scatter of the next).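

Among these compounds, at this aromatic carbon, ortho to a large group, the choice of substituent makes a measurable difference in this assay: fluoro in place of trifluoromethyl gives a 3.2-fold higher number from compound 1 to compound 4 (0.50 log units; beyond the scatter) and is the first single-place change seen in this set. The swap replaces a group of 4 heavy atoms with a group of 1 heavy atom and leaves the rest of the molecule untouched, so the shift in half-life belongs to this one site in this pair. Nothing available here explains why the half-life moves with this change.

A single pair cannot show whether the step comes from losing trifluoromethyl or from gaining fluoro, and a plain hydrogen, a chlorine, a methyl or a methoxy group on the same carbon would help to separate those two readings. Going by these compounds, it also remains open whether the same swap would give a step of similar size on another carbon of this aromatic ring, or whether an amine or a carboxylic acid at this site would move the half-life further.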